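The compounds below may be only part of what the source reports. "The series", "measured", "known", "first", "only" and "open" are said of these compounds alone.

- Compound 1 `CC(=O)OC[C@H]1CN(c2ccc(-n3cc(-c4ccccn4)cn3)c(F)c2)C(=O)O1`: > 400 ug/mL (a limit of the assay)
- Compound 2 `O=C1O[C@@H](Cn2ccnc2)CN1c1ccc(-n2cc(-c3ccccn3)cn2)c(F)c1`: 350 ug/mL

Going by the values given here, in an ADME assay on L02 cells (Homo sapiens) for cytotoxicity, read by MTT assay, with a stated time of 48 h (on this read-out higher numbers stand for weaker inhibition and lower numbers for stronger inhibition), compound 2 gives 350 ug/mL, the only actual number so far. For compound 1 the reading of > 400 ug/mL is a limit of the assay and not a number.

The next structure is compound 3 `CN(C)S(=O)(=O)NC[C@H]1CN(c2ccc(-n3cc(-c4ccccn4)cn3)c(F)c2)C(=O)O1`. The change is (dimethylsulfamoyl)amino in place of 1H-imidazol-1-yl on a saturated chain carbon bound to a saturated ring carbon.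

Among the compounds with values here, only one measured step bears on this place, the swap of acetoxy for 1H-imidazol-1-yl. That step is an at least 1.1-fold lower number from compound 1 to compound 2 (0.05 log units; that floor lies within the scatter), so it gives no sign that this place moves the read-out. It is also thin evidence, since it rests on (the limit of > 400 ug/mL in this assay, at which 1 of the 2 values shown sits). No step beyond the scatter is therefore expected in this assay, in either direction.

The expected step is a 1.1-fold higher number from compound 2 to compound 3 (0.02 log units; within the scatter), which is estimated to stay within the scatter. A reading that is only a limit is also expected to be quite possible. For compound 3 the estimate is 370 ug/mL, with an expected range from 180 ug/mL to 600 ug/mL.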

Compound 3, half-maximal inhibitory concentration: 158 ug/mL
The estimate for compound 3 lay 2.3-fold (0.37 log units) above the measured number; the whole stated range lies above it.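

In this assay, the place on a saturated chain carbon bound to a saturated ring carbon can clearly move the read-out: (dimethylsulfamoyl)amino in place of 1H-imidazol-1-yl gives a 2.2-fold lower number from compound 2 to compound 3 (0.35 log units; beyond the scatter), and a lower number here stands for stronger inhibition. Going by these compounds alone, the same group in place of acetoxy gives an at least 2.5-fold lower number from compound 1 to compound 3 (0.40 log units; beyond the scatter), whereas the earlier swap of acetoxy for 1H-imidazol-1-yl did not move beyond the scatter, so compound 3 is the first sign that the group at this place matters. Compound 1 reads > 400 ug/mL, which is a limit of the assay and not a number, so the step to compound 3 gives only a floor for the true size: the limit of > 400 ug/mL in this assay, at which 1 of the 3 values shown sits.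

This single change does not show which feature of the new group goes with the lower number, since (dimethylsulfamoyl)amino differs from 1H-imidazol-1-yl at once in its atoms, in having no ring and in bringing a hydrogen-bond donor. A simple amine or a carboxylic acid at the same place would help to show whether the sulfur-bearing part is needed for the step or whether other groups without a ring go the same way.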